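This account rests on a few compounds, and the source may have more. Where it says the series, first, only, none or still open, it means among the compounds named here.

Compound 1 `CCOC(=O)C1=Cc2ccccc2OC1(OCc1cn(CC(=O)Nc2ccc(OC)cc2)nn1)C(F)(F)F` belongs to a small set of compounds sharing one core, all tested in a functional assay on HeLa cells (Homo sapiens) for inhibition, read by MTT assay, with a stated time of 24 h; on this read-out lower numbers stand for stronger inhibition and higher numbers for weaker inhibition. Compound 1 gives 31900 nM in this assay. Compound 3 `CCOC(=O)C1=Cc2ccccc2OC1(OCc1cc(-c2ccc(Cl)cc2)no1)C(F)(F)F` gives 12300 nM, a lower number, and so compound 1 has the highest of the two plain numbers in this assay. Compound 2 `O=C(O)C1=Cc2ccccc2OC1(OCc1cc(-c2ccc([N+](=O)[O-])cc2)no1)C(F)(F)F` reaches only a limit of the assay, > 150000 nM, which is the limit of > 150000 nM in this assay, at which 1 of the 3 values shown sits. Compound 4 `CCOC(=O)C1=Cc2ccccc2OC1(OCc1cn(-c2ccc(C)cc2)nn1)C(F)(F)F` has not yet been measured in this assay. It differs from compound 1 in one place: 4-methylphenyl in place of ((4-methoxyphenyl)carbamoyl)methyl on an aromatic nitrogen. Among the measured compounds shown here, no measured pair traces this exact change, so the expected step from compound 1 to compound 4, a 1.3-fold lower number from compound 1 to compound 4 (0.11 log units; within the scatter), is modest and uncertain in direction. Compound 4 is thus estimated at 25000 nM, within 8000 nM to 80000 nM.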

Compound 4, half-maximal inhibitory concentration: 25100 nM
For compound 4 the middle estimate is 1.0-fold (0.00 log units) below the measured one; low and high end bracket the measured number.
By their numbers in this assay, from the lowest: compound 3; then compounds 4 and 1 (each within the scatter of the next). At a limit, above all of these: compound 2.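

Swapping the groups on this aromatic nitrogen gives a 1.3-fold lower number from compound 1 to compound 4 (0.10 log units; within the scatter), so in this assay compounds 1 and 4 read alike. At this position, the ((4-methoxyphenyl)carbamoyl)methyl group, with its hydrogen-bond donor and acceptors, can give way to 4-methylphenyl without a measurable difference; both groups carry a six-membered aromatic ring of carbon. Nothing shown here bears on why the two read alike. Still open, going by these compounds, is whether a group with no aromatic ring, such as a plain butyl chain or an aminoethyl group, would read the same on this nitrogen.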